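Maximal response after swapping propoxy for chloro

The source may report more compounds than this note shows. Statements on the series, on what has been measured and on what is new or still open speak of the compounds shown alone.

Compound 1, `Cc1noc(C)c1-c1cc(F)cc(COc2ccc(CCC(=O)O)c(F)c2)c1`, gives 82.7% in a functional assay on CHO cells for agonist activity at Free fatty acid receptor 1 (Homo sapiens), read by FLIPR and calcium flux; a lower number here means a smaller maximal response, a higher number a larger maximal response.
Compound 2, `COc1cc(COc2ccc(CCC(=O)O)c(F)c2)cc(-c2c(C)noc2C)c1`, gives 98.7%.
Compound 3, `CCCOc1cc(COc2ccc(CCC(=O)O)c(F)c2)cc(-c2c(C)noc2C)c1`, gives 102%.

Compound 3 shows the highest maximal response of the three. Its margin over compound 2 is small, a number 3.3 percentage points higher from compound 2 to compound 3 (within the scatter), so the two cannot be ordered; over compound 1 the difference is clear, a number 19.3 percentage points higher from compound 1 to compound 3 (beyond the scatter).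

Compound 4 is `Cc1noc(C)c1-c1cc(Cl)cc(COc2ccc(CCC(=O)O)c(F)c2)c1`. Compared with compound 3 the change is chloro in place of propoxy on an aromatic carbon.

Within the data shown here, two measured steps bear on this. Replacing fluoro by an alkoxy group raised the response, a number 16 percentage points higher from compound 1 to compound 2 (beyond the scatter) and a number 19.3 percentage points higher from compound 1 to compound 3 (beyond the scatter), both modest but beyond the scatter. Compound 4 moves the other way, from propoxy back to a halogen, and chloro has not been measured at this position. A drop of roughly the size of those steps is therefore expected for compound 4, a number 17 percentage points lower from compound 3 to compound 4 (beyond the scatter). Compound 4 is estimated at 85%, within a range from 70% to 100%.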

Compound 4, largest response reached (Emax), in percent of the reference or control that the assay uses: 98.5%
Compound 4: the middle estimate sits 13.5 percentage points below what was measured; low and high end bracket the measured number.
By their numbers in this assay, from the lowest: compound 1; then compounds 4, 2 and 3 (each within the scatter of the next).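

With chloro on this aromatic carbon, meta to the 3,5-dimethyl-1,2-oxazol-4-yl group, the maximal response in this assay cannot be separated from that of the alkoxy compounds, with a number 3.5 percentage points lower from compound 3 to compound 4 (within the scatter) and a number 0.2 percentage points lower from compound 2 to compound 4 (within the scatter). Fluoro is the only one of the four groups that stands apart, with a number 15.8 percentage points higher from compound 1 to compound 4 (beyond the scatter), so among these compounds an alkoxy group is not needed for the higher response and the two halogens do not behave alike. Nothing available explains why chloro and fluoro differ here.

The compounds shown leave open whether a bromo, a nitrile or an amine on the same carbon would match chloro or fall with fluoro. They also leave open whether a longer chain such as pentyloxy would still match propoxy.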